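The source may report more compounds than this note shows. Statements on the series, on what has been measured and on what is new or still open speak of the compounds shown alone.

Among the measured compounds shown here, compound 1 `O=C(NNc1ccccc1Cl)c1ccc(NS(=O)(=O)c2cnc(O)nc2O)cc1` is the only member of this small set with a numbered result in a functional assay on SGC-7901 cells (Homo sapiens) for antiproliferative activity, read by MTT assay, with a stated time of 24 h; on this read-out lower numbers stand for stronger inhibition and higher numbers for weaker inhibition: in that setting compound 1 gives 3630 nM. Compound 2 `Cc1ccccc1NNC(=O)c1cccc(NS(=O)(=O)c2cnc(O)nc2O)c1` in this assay gives > 20000 nM, which is a limit of the assay and not a number, namely (the limit of > 20000 nM in this assay, at which 1 of the 2 values shown sits). Compound 3 `O=C(NNC(=O)c1ccccc1F)c1ccc(NS(=O)(=O)c2cnc(O)nc2O)cc1` differs from compound 1 in one place: (2-fluorophenyl)carbonyl in place of 2-chlorophenyl on an amine nitrogen. For the measured compounds named here, no step between two measured compounds connects these structures, so no measured change of this kind is available to lean on. On that basis the step from compound 1 to compound 3 is expected to be small, either toward weaker inhibition or none beyond the usual scatter, which corresponds to an estimated 1.4-fold higher number from compound 1 to compound 3 (0.14 log units; within the scatter) in this assay. Compound 3 is therefore expected to give about 5000 nM in this assay, within a range from 1500 nM to 20000 nM.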

Compound 3, half-maximal inhibitory concentration: > 20000 nM
Compound 3: only a limit was reported; the forecaster's own chance of this, stated with the estimate: 30%; middle value at least 4.0-fold (0.60 log units) away from the limit.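

Among the compounds shown here, the change from 2-chlorophenyl to (2-fluorophenyl)carbonyl on this amine nitrogen gives the first measured step at this position, and in this assay it brings an at least 5.5-fold higher number from compound 1 to compound 3 (0.74 log units; beyond the scatter). The position is therefore not indifferent to this change, since the number seen with the 2-chlorophenyl group is lost once the (2-fluorophenyl)carbonyl group enters. Compound 3 gives a limit of the assay and not a number, so the true size of the step stays unknown: the limit of > 20000 nM in this assay, at which 2 of the 3 values shown sit.

The change swaps the halogen and adds a carbonyl at once, and the compounds shown cannot tell which of the two carries the loss. Going by these compounds, a 2-fluorophenyl or a (2-chlorophenyl)carbonyl group on the same nitrogen would separate the two, and how a plain phenyl group behaves at this position also remains open.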